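This account rests on a few compounds, and the source may have more. Where it says the series, first, only, none or still open, it means among the compounds named here.

Three related compounds were tested in a functional assay on MCF7 cells (Homo sapiens) for cytotoxicity, read by MTT assay, with a stated time of 24 h; a lower number here means a stronger inhibitor, a higher number a weaker inhibitor. Compound 1 `Cc1ccc(-c2nnc(N3CCN(C(=O)CN4CCN(c5ccc(Cl)cc5)CC4)CC3)nc2-c2ccc(C)cc2)cc1` gave a value of 660000 nM. Compound 2 `COc1ccc(-c2nnc(N3CCN(C(=O)CN4CCN(c5ccc(OC)cc5)CC4)CC3)nc2-c2ccc(OC)cc2)cc1` gave no number but only a limit of the assay, > 821000 nM. Compound 3 `O=C(CN1CCN(c2ccccc2)CC1)N1CCN(c2nnc(-c3ccc(Cl)cc3)c(-c3ccc(Cl)cc3)n2)CC1` likewise gave only a limit, > 850000 nM, so where it truly stands in this assay is not known. Compound 3 sits at the limit of > 850000 nM in this assay, at which 1 of the 3 values shown sits. Compound 2 sits at the limit of > 821000 nM in this assay, at which 1 of the 3 values shown sits. On the numbers shown, compound 3 therefore cannot be placed above or below the other two; all that is known is that it is at most weakly active.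

Compound 4 `COc1ccc(N2CCN(CC(=O)N3CCN(c4nnc(-c5ccc(Cl)cc5)c(-c5ccc(Cl)cc5)n4)CC3)CC2)cc1` differs from compound 3 in a single place: methoxy in place of hydrogen on an aromatic carbon. Among the measured compounds shown here, no pair of measured compounds shows this same change, so its effect in this assay cannot be read from the data. The step of a number no higher from compound 3 to compound 4 (the limit leaves the size open) is expected to be none beyond the scatter. Compound 4 is accordingly estimated at 850000 nM in this assay, in a range from 400000 nM to 2000000 nM, and most likely the assay will again report only a limit.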

Compound 4, half-maximal inhibitory concentration: > 809000 nM
Compound 4 ended at the assay's limit (the forecaster's own chance of this, stated with the estimate: 70%); the middle value does not contradict the limit.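

Among the compounds shown here, compound 3 and compound 4 both gave only a limit in this assay, not a number, and no step between them can be read. The compounds shown leave open whether methoxy in place of hydrogen on an aromatic carbon changes activity at all.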